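The source may report more compounds than this note shows. Statements on the series, on what has been measured and on what is new or still open speak of the compounds shown alone.

Measured so far:
Compound 1 `COc1cc2ccc(=O)oc2cc1OCCCOc1no[n+]([O-])c1S(=O)(=O)c1ccccc1` gives 2900 nM in a functional assay on HepG2 cells (Homo sapiens) for inhibition, read by MTT assay, with a stated time of 48 h; on this read-out lower numbers stand for stronger inhibition and higher numbers for weaker inhibition.
Compound 2 `COc1cc2ccc(=O)oc2cc1OCCCCOc1no[n+]([O-])c1S(=O)(=O)c1ccccc1` gives 3250 nM in this assay.
Compound 3 `COc1cc2ccc(=O)oc2cc1OCCCCCOc1c[n+]([O-])on1` gives 3420 nM in this assay.

All three numbers lie within the usual scatter of one another, so compound 3 cannot be set apart from compound 1 or compound 2 on this read-out. Compound 4 `COc1cc2ccc(=O)oc2cc1OCCCCCCOc1c[n+]([O-])on1` differs from compound 3 by a group of 8 heavy atoms (3 carbon, 2 nitrogen, 3 oxygen; one five-membered aromatic ring with 3 hetero atoms) in place of a group of 7 heavy atoms (2 carbon, 2 nitrogen, 3 oxygen; one five-membered aromatic ring with 3 hetero atoms), on a saturated chain carbon, five bonds along the chain from an oxygen on an aromatic ring. For the measured compounds named here, no step between two measured compounds isolates a change of this kind, so the expectation rests on compound 3 and its value of 3420 nM, which sits close to the other two. The step from compound 3 to compound 4 is expected to stay within the scatter, with an estimated step of a 1.0-fold higher number from compound 3 to compound 4 (0.01 log units; within the scatter). For compound 4 the estimated value in this assay is 3500 nM, within a range from 1700 nM to 7000 nM.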

Compound 4, half-maximal inhibitory concentration: 3790 nM
Compound 4: the middle estimate sits 1.1-fold (0.03 log units) below what was measured, within the range that was stated.
By their numbers in this assay, from the lowest: compounds 1, 2, 3 and 4 (each within the scatter of the next).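

This is the only pair shown that differs in one place. On a saturated chain carbon, five bonds along the chain from an oxygen on an aromatic ring, the group of 8 heavy atoms in place of the group of 7 heavy atoms gives a 1.1-fold higher number from compound 3 to compound 4 (0.04 log units; within the scatter) in this assay and that step lies within the usual scatter. This read-out therefore does not separate these two groups at this position, and no supporting data are available to explain the result. Still open, on these data alone, is whether a much longer chain, or an amine on the chain, would move the number beyond the scatter.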